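From bromo to chloro: estimating compound 4

The source may report more compounds than this note shows. Statements on the series, on what has been measured and on what is new or still open speak of the compounds shown alone.

Measured in a functional assay on HeLa cells (Homo sapiens) for cytotoxicity, read by sulforhodamine B assay, with a stated time of 48 h; on this read-out higher numbers stand for weaker inhibition and lower numbers for stronger inhibition
- Compound 1 `C=CCOc1cc(Br)ccc1C(=O)c1cccnc1` gives > 100000 nM (a limit, not a number)
- Compound 2 `O=C(c1cccnc1)c1cc(Cl)ccc1O` gives 24000 nM
- Compound 3 `C=CCOc1ccc(Br)cc1C(=O)c1cccnc1` gives 96000 nM

Compound 1 is known only as a limit of the assay. Compound 3 gives 96000 nM as the higher of the two real numbers. Compound 2 gives 24000 nM as the nearest value, lower by more than the usual scatter.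

Compound 4 `C=CCOc1ccc(Cl)cc1C(=O)c1cccnc1` differs from compound 3 in one place, with chloro in place of bromo on an aromatic carbon, para to an allyloxy group (chloro in place of bromo on an aromatic carbon). Within the data shown here, no measured pair shows this swap on its own, so the expectation starts from compound 3 at 96000 nM and assumes little movement. In this assay the expected change is a 1.2-fold lower number from compound 3 to compound 4 (0.08 log units; within the scatter) and it is not expected to go beyond the scatter. Compound 4 is estimated at 80000 nM with an expected range from 40000 nM to 100000 nM for the coming measurement.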

Compound 4, half-maximal inhibitory concentration: 75000 nM
The estimate for compound 4 lay 1.1-fold (0.03 log units) above the measured number; the range from low to high includes it.
By their numbers in this assay, from the lowest: compound 2; then compounds 4 and 3 (each within the scatter of the next). At a limit, above all of these: compound 1.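

This pair isolates one change, chloro in place of bromo on an aromatic carbon para to an allyloxy group, and in this assay that swap stays within the scatter (a 1.3-fold lower number from compound 3 to compound 4 (0.11 log units; within the scatter)), so these two halogens cannot be told apart at this position. Allyl in place of hydrogen on an oxygen on an aromatic ring, by contrast, gives a modest step beyond the scatter (a 3.1-fold higher number from compound 2 to compound 4 (0.49 log units; beyond the scatter)). The weak end of this scale also has a ceiling, and compound 1 sits at that limit rather than at a number: the limit of > 100000 nM in this assay, at which 1 of the 4 values shown sits.

Among these compounds, the halogen swap is seen here with only one group on the oxygen, so it stays open whether it would behave the same with a hydrogen or a longer chain there. An amine or a carboxylic acid in place of the halogen also remains untested among these compounds.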